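A few compounds are considered here, and "the series" means these few. Any claim that something is new, unique, unknown or untested is made for them only; others in the source may bear on it.

Measured so far:
- Compound 1, `COc1ccc(Nc2sc(C(=O)c3ccc(OC)cc3)c(C)c2C(=O)O)cc1`: 30.6%
- Compound 2, `COc1ccc(C(=O)c2sc(Nc3ccc(F)cc3)c(C(=O)O)c2C)cc1`: 1.98%

In a functional assay, with a stated time of 150 min, tested at 15 ug/mL (on this read-out lower numbers stand for a weaker effect and higher numbers for a stronger effect at the one concentration tested), compound 2 stands lowest of the two numbers shown; its nearest neighbour is compound 1, reached by a number 28.6 percentage points lower from compound 1 to compound 2 (beyond the scatter), a change of methoxy to fluoro. Compound 3, `COc1ccc(C(=O)c2sc(Nc3ccc(Cl)cc3)c(C(=O)O)c2C)cc1`, differs from compound 2 by chloro in place of fluoro on an aromatic carbon. For the measured compounds named here, no measured step swaps fluoro for chloro, so only the modest step from compound 1 to compound 2 bears on it, and only loosely. For compound 3 a small rise is expected, a number 6 percentage points higher from compound 2 to compound 3 (within the scatter), most likely within the scatter. The estimate for compound 3 is 8%, ranging from 0% to 30%.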

Compound 3, a percentage reported as activity, at one concentration (the size of the read-out at that concentration, not a potency): "not active" (no number reported)
Compound 3: no number reported; the estimate stays without a comparison.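

In this assay, for the compounds shown here, compound 3 is reported as not active without a number, so no step from compound 2 to compound 3 can be read. Nothing at hand explains this result. The compounds shown leave open how 4-chlorophenyl compares numerically with 4-fluorophenyl.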